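This account rests on a few compounds, and the source may have more. Where it says the series, first, only, none or still open, it means among the compounds named here.

Compound 1 `CN(C)c1ncnc2c1c(-c1ccsc1)cn2[C@@H]1O[C@H](CO)[C@@H](O)[C@H]1O` in a functional assay on K562 cells (Homo sapiens), read by MTT assay, with a stated time of 72 h (a lower number here means a stronger inhibitor, a higher number a weaker inhibitor), gives > 20000 nM, which is a limit of the assay rather than a number.
Compound 2 `CSc1ncnc2c1c(-c1ccccc1)cn2[C@@H]1O[C@H](CO)[C@@H](O)[C@H]1O` in this assay gives > 20000 nM, again only a limit.
Compound 3 `CNc1ncnc2c1c(-c1ccccc1)cn2[C@@H]1O[C@H](CO)[C@@H](O)[C@H]1O` in this assay gives > 20000 nM, once more a limit.

Compound 2 thus stands at the limit, and so does every other value shown (the limit of > 20000 nM in this assay, at which 3 of the 3 values shown sit). For the measured compounds named here, the one step with a single change, a step that the two limits leave unreadable from compound 2 to compound 3, runs from one limit to another, so its size cannot be read. Compound 4 `CSc1ncnc2c1c(-c1cccs1)cn2[C@@H]1O[C@H](CO)[C@@H](O)[C@H]1O` differs from compound 2 by thiophen-2-yl in place of phenyl on an aromatic carbon. Going by the values given here, no measured step follows this change. Compound 1 carries a thiophen-3-yl group but differs from compound 2 in a second place as well, and both of their values are limits, so together they show only that nothing here has yet reached a readable number. The expectation for compound 4 is accordingly that a step that the limit leaves unreadable from compound 2 to compound 4 stays within the scatter, with no readable shift. Compound 4 is estimated at 30000 nM, between 10000 nM and 100000 nM, most likely reported again as a limit.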

Compound 4, half-maximal inhibitory concentration: > 20000 nM
Compound 4 gave a limit, no number; the forecaster's own chance of this, stated with the estimate: 85%; the middle value is on the limit's open side.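

For the compounds shown here, compound 4 also gives > 20000 nM, which is a limit and not a number, so no step in size can be read between compound 2 and compound 4. Every value so far sits at one limit: the limit of > 20000 nM in this assay, at which 4 of the 4 values shown sit.

What the compounds shown leave open is whether any change to this shared core gives a readable number in this assay.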